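Compound 3 to compound 4: methoxy in place of hydrogen

The source may hold more compounds than are shown below. What is called first, only, known or untested is meant among the compounds shown, and "the series" means these compounds.

In a functional assay on MCF7 cells (Homo sapiens) for antiproliferative activity, read by sulforhodamine B assay, with a stated time of 72 h (on this read-out higher numbers stand for weaker inhibition and lower numbers for stronger inhibition), compound 1 (`CCOc1cc2occ(-c3csc4ccccc34)c(=O)c2c(OCC)c1OC`) gives 3100 nM. Compound 2 (`COc1cc2c(=O)c(-c3csc4ccccc34)coc2c(OC)c1OC`) reads > 10000 nM, which is a limit of the assay and not a number. Compound 3 (`O=C(/C=C/c1csc2ccccc12)c1ccccc1O`) gives 6600 nM, the higher of the two actual numbers, and its gap to compound 1 lies beyond the scatter. Compound 4 (`COc1ccc(O)c(C(=O)/C=C/c2csc3ccccc23)c1`) carries a methoxy in place of hydrogen on an aromatic carbon of compound 3, meta to a large group and para to a hydroxy group: methoxy in place of hydrogen on an aromatic carbon. Going by the values given here, no measured pair isolates this change. No step beyond the scatter is expected in this assay, with a slight lean toward stronger inhibition. The estimated step is a 1.2-fold lower number from compound 3 to compound 4 (0.08 log units; within the scatter). For compound 4 the estimated value is 5500 nM, with an expected range of 2200 nM to 10000 nM.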

Compound 4, half-maximal inhibitory concentration: 750 nM
For compound 4 the middle estimate is 7.3-fold (0.87 log units) above the measured one; measured number below the stated range.
By their numbers in this assay, from the lowest: compound 4; then compound 1; then compound 3. At a limit, above all of these: compound 2.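

In this assay, going by these compounds alone, methoxy in place of hydrogen on this aromatic carbon, para to a hydroxy group, gives the first single-place step, an 8.8-fold lower number from compound 3 to compound 4 (0.94 log units; beyond the scatter). This one pair shows that the position accepts the methoxy and that inhibition strengthens with it. Nothing at hand bears on the cause of this step.

On these data alone, it remains open whether the gain is specific to methoxy, or whether a chlorine or an amine on the same carbon would match it. As far as these compounds go, the role of the hydroxy group in this step also remains open.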